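A few compounds are considered here, and "the series" means these few. Any claim that something is new, unique, unknown or untested is made for them only; others in the source may bear on it.

Of the compounds shown here, three have been measured so far in an ADME assay on microsomes (Homo sapiens) for metabolic stability; a lower number here means that the compound disappears faster, a higher number that the compound lasts longer. Compound 1 `CC(C)(C)C(=O)N1CCSC1c1ccccc1` gives a plain number, 0.3 h. Compound 2 `CC(C)(C)C(=O)N1N=CCC1c1cocn1` is reported only as a limit, > 1.5 h. Compound 3 `CCC(=O)N1CCC(C(=O)N2N=CCC2c2ccccc2)CC1` is also reported only as a limit, > 2.75 h, so its exact half-life is not known.

Compound 4 `O=C(c1c[nH]nn1)N1CCC(C(=O)N2N=CCC2c2ccccc2)CC1` keeps most of compound 3 and changes one group: 1H-1,2,3-triazol-4-yl in place of ethyl on a carbonyl carbon. Here 1H-1,2,3-triazol-4-yl takes the place of ethyl on a carbonyl carbon, which turns propanoyl into (1H-1,2,3-triazol-4-yl)carbonyl. Within the data shown here, no two measured compounds differ in only one place, so the data show no direct precedent for this swap.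

The estimate therefore rests on compound 3 at > 2.75 h, which is itself a limit. The expected step that the limit leaves unreadable from compound 3 to compound 4 is small, with no firm direction and nothing expected beyond the usual scatter. For compound 4 the estimated half-life is 3 h, with an expected range from 1.2 h to 7 h.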

Compound 4, half-life: > 2.75 h
Compound 4 ended at the assay's limit (the forecaster's own chance of this, stated with the estimate: 55%); the middle value lies beyond the limit too.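

Among these compounds, compound 3 and compound 4 are both reported only as limits, and no step between them can be read in this assay. The compounds shown leave open the actual half-life of each, and whether 1H-1,2,3-triazol-4-yl in place of ethyl changes it at all.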